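A few compounds are considered here, and "the series" means these few. Any claim that something is new, unique, unknown or untested is made for them only; others in the source may bear on it.

Going by the values given here, compound 2 `c1cnc(N2CCN(CCCc3c[nH]c4ccc(-n5cnnc5)cc34)CC2)nc1` gives 0.5 nM in an assay on CHO cells for displacement of a labelled ligand from 5-hydroxytryptamine receptor 1B (Homo sapiens) (on this read-out higher numbers stand for weaker inhibition and lower numbers for stronger inhibition), the lowest of the two numbers measured so far. Among the compounds with values here, its nearest neighbour is compound 1 `CC(=O)Nc1ccc(CN2CCN(CCCc3c[nH]c4ccc(-n5cnnc5)cc34)CC2)cc1`, which in this assay gives 56 nM; the single step between them, a 110-fold lower number from compound 1 to compound 2 (2.05 log units; beyond the scatter), is large. Compound 3 `c1ccc(CCCN2CCN(CCCc3c[nH]c4ccc(-n5cnnc5)cc34)CC2)cc1` has not yet been measured in this assay. It differs from compound 2 in one place: 3-phenylpropyl in place of pyrimidin-2-yl on an amine nitrogen in a ring. Within the data shown here, the only step available that bears on this position is the one from compound 1 to compound 2, in which an aryl group joined through a chain gave way to pyrimidin-2-yl and the number fell steeply. Since 3-phenylpropyl again attaches a carbon-only aromatic ring through a chain, a step upward beyond the scatter is expected for compound 3, of about a 30-fold higher number from compound 2 to compound 3 (1.48 log units; beyond the scatter). Compound 3 is therefore estimated at 15 nM, within a range of 2 nM to 100 nM.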

Compound 3, half-maximal inhibitory concentration: 85 nM
The estimate for compound 3 lay 5.7-fold (0.75 log units) below the measured number; the range from low to high includes it.
By their numbers in this assay, from the lowest: compound 2; then compounds 1 and 3 (each within the scatter of the next).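

Replacing pyrimidin-2-yl with 3-phenylpropyl on the amine nitrogen in the ring gives, in this assay, a 170-fold higher number from compound 2 to compound 3 (2.23 log units; beyond the scatter), so the low number of compound 2 now stands out against two different groups rather than one. The comparison of the two chain-linked groups gives a 1.5-fold higher number from compound 1 to compound 3 (0.18 log units; within the scatter), which lies within the scatter, so this assay does not separate the 4-acetamidobenzyl of compound 1 from the 3-phenylpropyl of compound 3. Nothing available explains the gap between pyrimidin-2-yl and these two groups.

The compounds shown leave open whether the low number depends on the two ring nitrogens of pyrimidin-2-yl or on an aromatic ring attached without a chain, which a phenyl or a pyridin-2-yl group on the same nitrogen would help to separate. They also leave open what an unsubstituted benzyl group would give.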